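Sulfonamide series: methyl to trifluoromethyl on the anilide ring

The compounds below may be only part of what the source reports. "The series", "measured", "known", "first", "only" and "open" are said of these compounds alone.

Three compounds of this series carry a measured number in a functional assay on MCF7 cells (Homo sapiens) for inhibition, read by CCK-8 assay, with a stated time of 72 h; on this read-out lower numbers stand for stronger inhibition and higher numbers for weaker inhibition. Compound 1 `O=C(/C=C/c1cccnc1)NCCCCCCCc1ccc(S(=O)(=O)Nc2ccccc2)cc1` gives 37.6 nM in this assay. Compound 2 `O=C(/C=C/c1cccnc1)NCCCCCc1cccc(S(=O)(=O)Nc2ccccc2)c1` gives 12.5 nM in this assay. Compound 3 `Cc1ccc(NS(=O)(=O)c2cccc(CCCCCCNC(=O)/C=C/c3cccnc3)c2)cc1` gives 1.97 nM in this assay, the lowest of the three numbers: compound 2 sits the nearest to it and compound 1 the furthest from it, and both gaps are beyond the scatter, so compound 3 is the most potent of the measured set.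

Compound 4 `O=C(/C=C/c1cccnc1)NCCCCCCc1cccc(S(=O)(=O)Nc2ccc(C(F)(F)F)cc2)c1` has not been measured. It differs from compound 3 in one place: trifluoromethyl in place of methyl on an aromatic carbon. Within the data shown here, no measured pair in the set shows this kind of change, so no step size can be read off for it. The expectation is a small step from compound 3 to compound 4, a 1.8-fold higher number from compound 3 to compound 4 (0.25 log units; within the scatter), on the side of a somewhat higher number but not clearly beyond the scatter. Compound 4 is accordingly estimated at 3.5 nM in this assay, with a range from 0.9 nM to 14 nM.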

Compound 4, half-maximal inhibitory concentration: 67.8 nM
Beside the measured number, compound 4's estimate is 19-fold (1.29 log units) below it; measured number outside the range, above it.
By their numbers in this assay, from the lowest: compound 3; then compound 2; then compounds 1 and 4 (each within the scatter of the next).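

In this assay, among these compounds, this is the first step that changes one place only: trifluoromethyl in place of methyl on an aromatic carbon, para to a large group, gives a 34-fold higher number from compound 3 to compound 4 (1.54 log units; beyond the scatter). The substituent on this carbon therefore has a large effect on the read-out, and methyl and trifluoromethyl are not interchangeable here, even though neither adds a ring, a hydrogen-bond donor or acceptor, or a net charge. No measurement at hand accounts for the size of this step.

This single pair leaves open whether methyl favours the number or trifluoromethyl disfavours it, and a hydrogen on this carbon with the same chain would separate the two. Going by these compounds, how a chlorine, a methoxy group or an amine would fare on this carbon also remains open.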